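One stereocentre changed: what happens to compound 3?

The source may report more compounds than this note shows. Statements on the series, on what has been measured and on what is new or still open speak of the compounds shown alone.

Measured in an ADME assay on liver (Homo sapiens) for metabolic stability, read by LC-MS, using microsomes and NADPH; a lower number here means that less of the compound is left, a higher number that more of the compound is left:
- compound 1 `CCCN(Cc1ccc(OCCN2C(=O)CCC2=O)c(C)c1)C(CC(=O)O)c1ccc(Cl)cc1`: 85%
- compound 2 `CCCN(Cc1ccc(OCCN2C(=O)CCC2=O)c(C)c1)[C@@H](CC(=O)O)c1ccc(Cl)cc1`: 97%

Of these two, compound 2 stands highest at 97%. Compound 3 `CCCN(Cc1ccc(OCCN2C(=O)CCC2=O)c(C)c1)[C@H](CC(=O)O)c1ccc(Cl)cc1` differs from it in one way: the two compounds have the same atoms and bonds and differ only in configuration as drawn: 1 of 1 stereo elements differ; a stereocentre at a saturated chain carbon is drawn S in compound 2 and R in compound 3. Going by the values given here, the only measured step that bears on this is a number 12 percentage points higher from compound 1 to compound 2 (beyond the scatter), and it rests on (the fact that one of compounds 1 and 2 is drawn with a defined configuration and the other without, at the place where they differ). If compound 1 holds both configurations in equal parts, which the data do not state, its 85% would be a blend, and the R form would lie below it. A fall in this assay is therefore expected, with an estimated a number 21 percentage points lower from compound 2 to compound 3 (beyond the scatter). For compound 3 the estimate is 76%, with an expected range of 60% to 92%.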

Compound 3, percent of the compound remaining: 100%
Compound 3: the middle estimate sits 24 percentage points below what was measured, and the stated range ends below it.
By their numbers in this assay, from the lowest: compound 1; then compounds 2 and 3 (each within the scatter of the next).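

In this assay, turning this stereocentre from S to R gives a number 3 percentage points higher from compound 2 to compound 3 (within the scatter), so the two drawn forms cannot be told apart here, and the configuration at this carbon shows no effect on the number. The new comparison with the undrawn form gives a number 15 percentage points higher from compound 1 to compound 3 (beyond the scatter), which places compound 1 apart from both single forms rather than between them, so an equal blend of the two would not account for its number.

On these data alone, what sets compound 1 apart stays open. So does whether the two configurations would still stay level with a primary amide in place of the carboxylic acid.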